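Cyano in Place of Fluoro: What Compound 3 May Show

The compounds below may be only part of what the source reports. "The series", "measured", "known", "first", "only" and "open" are said of these compounds alone.

Compound 1 `COc1ccc(N2CCN(C(=S)SCc3ccc(C(=O)Nc4ccccc4N)cc3)CC2)cc1`: 25.3%
Compound 2 `Nc1ccccc1NC(=O)c1ccc(CSC(=S)N2CCN(c3ccc(F)cc3)CC2)cc1`: 18.8%

Going by the values given here, in a functional assay on MGC-803 cells (Homo sapiens) for antiproliferative activity, read by CCK-8 assay, with a stated time of 72 h, tested at 2 uM (a higher number here means a stronger effect of the compound at the concentration tested, a lower number a weaker effect), compound 2 gives the lowest of the two numbers, and the only measured step, a number 6.5 percentage points lower from compound 1 to compound 2 (within the scatter), lies within the scatter. Compound 3 `N#Cc1ccc(N2CCN(C(=S)SCc3ccc(C(=O)Nc4ccccc4N)cc3)CC2)cc1` differs from compound 2 by cyano in place of fluoro on an aromatic carbon. Among the compounds with values here, this change sits at the same place, para to a large group, as the one step already measured, which bears on it directly. Compound 3 is expected to move no further than the scatter, an estimated a number 3.2 percentage points higher from compound 2 to compound 3 (within the scatter), because a number 6.5 percentage points lower from compound 1 to compound 2 (within the scatter) stayed within it. Compound 3 is therefore estimated at 22%, within 10% to 35%.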

Compound 3, a percentage reported as inhibition, at one concentration (the size of the read-out at that concentration, not a potency): 34.5%
Compound 3: middle estimate off by 12.5 percentage points, on the low side; the range from low to high includes it.
By their numbers in this assay, from the lowest: compounds 2, 1 and 3 (each within the scatter of the next, the first and the last beyond it).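

In this assay, going by these compounds alone, cyano in place of fluoro, para to a large group, gives a number 15.7 percentage points higher from compound 2 to compound 3 (beyond the scatter) and so the first step at this position that clears the scatter. Cyano in place of methoxy gives only a number 9.2 percentage points higher from compound 1 to compound 3 (within the scatter) and so fluoro and cyano are told apart here, while methoxy and cyano are not. Nothing available explains this difference. As far as these compounds go, it remains open how an amine, a carboxylic acid or a longer chain at this same place would compare with the cyano of compound 3.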